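The compounds below may be only part of what the source reports. "The series", "measured", "known", "first", "only" and "open" are said of these compounds alone.

Of the compounds shown here, three sharing one core have been measured in an assay on LtK cells with ATP-sensitive inward rectifier potassium channel 11 (Homo sapiens) as the target; on this read-out higher numbers stand for an effect only at larger amounts of compound and lower numbers for an effect already at smaller amounts. Compound 1 `CC(C)C(=O)Nc1c(C(O)(C(F)(F)F)C(F)(F)F)ccc2ccccc12` gives 6630 nM. Compound 2 `CC(C)OC(=O)Nc1c(C(O)(C(F)(F)F)C(F)(F)F)ccc2ccccc12` gives 1160 nM in this assay, which places it second highest of the three numbers. Compound 3 `O=C(Nc1c(C(O)(C(F)(F)F)C(F)(F)F)ccc2ccccc12)c1cccc(Cl)c1` gives 98 nM in this assay, the lowest of the three. Exchanging the group on the carbonyl carbon produced a 5.7-fold lower number from compound 1 to compound 2 (0.76 log units; beyond the scatter) and a 68-fold lower number from compound 1 to compound 3 (1.83 log units; beyond the scatter), and the step most relevant here, a 12-fold lower number from compound 2 to compound 3 (1.07 log units; beyond the scatter), in which an aromatic ring replaced the isopropoxy group.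

Compound 4 `O=C(Nc1c(C(O)(C(F)(F)F)C(F)(F)F)ccc2ccccc12)c1ccc(C(F)(F)F)cc1` has not yet been measured. It differs from compound 2 by 4-(trifluoromethyl)phenyl in place of isopropoxy on a carbonyl carbon. Like compound 3, it carries a six-membered aromatic ring of carbon only on the carbonyl carbon, though with a different substituent on that ring. Because compound 3 reached 98 nM after the same kind of exchange, a step of similar size and direction is expected, a 9.7-fold lower number from compound 2 to compound 4 (0.99 log units; beyond the scatter). Compound 4 is therefore estimated at 120 nM in this assay, with a likely range from 40 nM to 400 nM.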

Compound 4, half-maximal effective concentration: 160 nM
Beside the measured number, compound 4's estimate is 1.3-fold (0.12 log units) below it, within the range that was stated.
By their numbers in this assay, from the lowest: compounds 3 and 4 (each within the scatter of the next); then compound 2; then compound 1.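

In this assay, compound 4 shows that compound 3 was not a lone case: a second substituted phenyl ring on the carbonyl carbon also brings the number well down from the ring-free groups (a 7.3-fold lower number from compound 2 to compound 4 (0.86 log units; beyond the scatter) and a 41-fold lower number from compound 1 to compound 4 (1.62 log units; beyond the scatter)). The two ring compounds cannot be told apart (a 1.6-fold higher number from compound 3 to compound 4 (0.21 log units; within the scatter), within the scatter), so this position tolerates a change from 3-chlorophenyl to 4-(trifluoromethyl)phenyl, in which both the substituent and its place on the ring differ. Nothing available here explains why these rings give lower numbers than isopropyl or isopropoxy.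

On these data alone, it remains open whether a plain phenyl ring with no substituent would read the same as these two rings. Also open, as far as these compounds go, is how a pyridine ring, or a carboxylic acid or an amine on the phenyl ring, would read at this position.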